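Carbamate alkyl swap in the cyclohexyl ether series

This account rests on a few compounds, and the source may have more. Where it says the series, first, only, none or still open, it means among the compounds named here.

Compound 1 `CC(C)(C)OC(=O)N1CCC(O[C@H]2CC[C@H](Oc3cnc(S(C)(=O)=O)cn3)CC2)CC1` holds the lowest of the two numbers in a functional assay on isolated protein for agonist activity at Glucose-dependent insulinotropic receptor (Rattus norvegicus), read by HTRF and cAMP accumulation; on this read-out higher numbers stand for an effect only at larger amounts of compound and lower numbers for an effect already at smaller amounts; in this assay compound 1 gives 64 nM. Its nearest neighbour, compound 2 `CC(C)(C)OC(=O)N1CCC(O[C@H]2CC[C@H](Oc3ccc(S(C)(=O)=O)nn3)CC2)CC1`, gives 1160 nM, and the step of an 18-fold higher number from compound 1 to compound 2 (1.26 log units; beyond the scatter) rests on the heteroaryl end of the molecule alone. Compound 3 `CC1(OC(=O)N2CCC(O[C@H]3CC[C@H](Oc4cnc(S(C)(=O)=O)cn4)CC3)CC2)CC1` differs from compound 1 at the other end: 1-methylcyclopropyl in place of tert-butyl on an oxygen next to a carbonyl group. Among the compounds with values here, no measured step touches this position; the only step on record, from compound 1 to compound 2, leaves the tert-butyl group untouched and so says nothing about its replacement. With nothing in the data pointing either way, the step of no change at the digits printed from compound 1 to compound 3 (within the scatter) is expected to stay within the scatter. For compound 3 in this assay the estimate is therefore 64 nM, with a range from 20 nM to 200 nM to cover the lack of any bearing step.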

Compound 3, half-maximal effective concentration: 138 nM
Compound 3: the middle estimate sits 2.2-fold (0.33 log units) below what was measured; measured number inside the range.
By their numbers in this assay, from the lowest: compound 1; then compound 3; then compound 2.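

Carbamate end, working notes: in this assay, 1-methylcyclopropyl in place of tert-butyl gives a 2.2-fold higher number from compound 1 to compound 3 (0.33 log units; beyond the scatter), a modest step but one beyond the scatter, so this position is not silent, although the step is smaller than an 18-fold higher number from compound 1 to compound 2 (1.26 log units; beyond the scatter) at the heteroaryl end. The two groups match at 4 heavy atoms, all carbon, and differ in the one three-membered ring of the entering group, so a swap that keeps the heavy-atom count still registers on this read-out. No supporting data explain the size or direction of this step.

Open: whether a cyclobutyl, an isopropyl or a 1-(trifluoromethyl)cyclopropyl group on this oxygen would return the number towards that of compound 1 or move it further away. Also open, as far as these compounds go, is whether the same swap would give a similar step on the 6-(methylsulfonyl)pyridazin-3-yl end of compound 2.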